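A few compounds are considered here, and "the series" means these few. Any claim that something is new, unique, unknown or untested is made for them only; others in the source may bear on it.

Compound 1 `CN(C)C(=O)c1cc2cnc(Nc3ccc(NC(=O)C4(C(=O)Nc5cccc(O)c5)CC4)cc3)nc2n1C1CCCC1` gives 80.7% in a functional assay on T47D cells (Homo sapiens) for inhibition, read by CCK-8 assay, with a stated time of 72 h, tested at 1 uM; on this read-out higher numbers stand for more inhibition of growth at the one concentration tested and lower numbers for less inhibition of growth. Compound 2 `CN(C)C(=O)c1cc2cnc(Nc3ccc(NC(=O)C4(C(=O)Nc5cccc(C(F)(F)F)c5)CC4)cc3)nc2n1C1CCCC1` gives 9.7% in this assay, while compound 3 `CN(C)C(=O)c1cc2cnc(Nc3ccc(NC(=O)C4(C(=O)Nc5ccc(C(F)(F)F)cc5)CC4)cc3)nc2n1C1CCCC1` gives 29.6%. The cores of compound 2 and compound 3 differ by 4-(trifluoromethyl)phenyl in place of 3-(trifluoromethyl)phenyl on an amide-type nitrogen, a change that made a number 19.9 percentage points higher from compound 2 to compound 3 (beyond the scatter). The change hydroxy in place of trifluoromethyl on an aromatic carbon made a number 71 percentage points higher from compound 2 to compound 1 (beyond the scatter), and in the other direction a number 51.1 percentage points lower from compound 1 to compound 3 (beyond the scatter) was seen. Compound 4 `CN(C)C(=O)c1cc2cnc(Nc3ccc(NC(=O)C4(C(=O)Nc5ccc(O)cc5)CC4)cc3)nc2n1C1CCCC1` carries the same kind of change from compound 3, namely (hydroxy in place of trifluoromethyl on an aromatic carbon); the places are not identical, since here the group sits para to a large group, whereas in compound 1 it sits meta to a large group. Compound 4 is expected to show a step of a number 38.4 percentage points higher from compound 3 to compound 4 (beyond the scatter) in this assay, resting on compound 2 and compound 1 because a number 71 percentage points higher from compound 2 to compound 1 (beyond the scatter) was large. Compound 4 is therefore estimated at 68%, between 40% and 88%.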

Compound 4, percent growth inhibition at one concentration: 91.5%
Beside the measured number, compound 4's estimate is 23.5 percentage points below it, outside the stated range (above it).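

In this assay, hydroxy in place of trifluoromethyl gave a number 61.9 percentage points higher from compound 3 to compound 4 (beyond the scatter), and this step matched the earlier one on the other core: the same change on two cores in this assay, a number 71 percentage points higher (beyond the scatter) from compound 2 to compound 1 and a number 61.9 percentage points higher (beyond the scatter) from compound 3 to compound 4, 9.1 percentage points apart, within the scatter of two such steps

Moving from 3-hydroxyphenyl to 4-hydroxyphenyl gave a number 10.8 percentage points higher from compound 1 to compound 4 (beyond the scatter), while 4-hydroxyphenyl in place of 3-(trifluoromethyl)phenyl gave a number 81.8 percentage points higher from compound 2 to compound 4 (beyond the scatter). This shows the change carrying over between just these two pairs, at one concentration, and does not show that it would carry over to other cores or explain why the step occurs.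

The compounds shown leave open whether an amine, a carboxylic acid or a methoxy group on that aromatic carbon would behave like hydroxy or like trifluoromethyl.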